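Swapping 2H-tetrazol-5-yl for methoxycarbonyl in compound 3

The compounds below may be only part of what the source reports. "The series", "measured", "known", "first", "only" and "open" are said of these compounds alone.

Of the compounds shown here, three sharing one core have been tested in an ADME assay on HEp-2 cells (Homo sapiens) for cytotoxicity (on this read-out lower numbers stand for higher toxicity in this test and higher numbers for lower toxicity in this test), and they differ only in a single group on an aromatic carbon. Compound 1 `CC(C)CCn1c(Cn2c(=O)n(C(C)C)c3ccccc32)nc2cc(CNS(C)(=O)=O)ccc21` gives 30800 nM, compound 2 `CC(C)CCn1c(Cn2c(=O)n(C(C)C)c3ccccc32)nc2cc(Br)ccc21` gives 18100 nM, and compound 3 `CC(C)CCn1c(Cn2c(=O)n(C(C)C)c3ccccc32)nc2cc(-c3nn[nH]n3)ccc21` gives 2000 nM, the lowest of the three numbers. The next compound, compound 4 `COC(=O)c1ccc2c(c1)nc(Cn1c(=O)n(C(C)C)c3ccccc31)n2CCC(C)C`, keeps the core and changes that same group: methoxycarbonyl in place of 2H-tetrazol-5-yl on an aromatic carbon. In words, methoxycarbonyl takes the place of 2H-tetrazol-5-yl.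

For the measured compounds named here, no measured step involves methoxycarbonyl, so the evidence is indirect. Bringing in 2H-tetrazol-5-yl gave a 15-fold lower number from compound 1 to compound 3 (1.19 log units; beyond the scatter), a large step, and a 9.1-fold lower number from compound 2 to compound 3 (0.96 log units; beyond the scatter), a modest one. Exchanging the other two groups gave only a 1.7-fold lower number from compound 1 to compound 2 (0.23 log units; within the scatter), which lies within the scatter. Among these three compounds, then, the one carrying 2H-tetrazol-5-yl stands apart, and removing that group may return the number towards the other two. Three compounds are a thin basis, and a new group could behave differently, so the range must stay wide. The expected change in this assay is a 7.0-fold higher number from compound 3 to compound 4 (0.85 log units; beyond the scatter), a rise of modest size. For compound 4 the estimated value is 14000 nM, with an expected range of 5000 nM to 35000 nM.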

Compound 4, half-maximal cytotoxic concentration: 33700 nM
Compound 4: middle estimate off by 2.4-fold (0.38 log units), on the low side; the measured number falls inside the stated range.
By their numbers in this assay, from the lowest: compound 3; then compounds 2, 1 and 4 (each within the scatter of the next).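

In this assay methoxycarbonyl reverses the drop that came with 2H-tetrazol-5-yl, and a 17-fold higher number from compound 3 to compound 4 (1.23 log units; beyond the scatter) is a large step. Set against the two other groups, the new group makes no clear difference: a 1.9-fold higher number from compound 2 to compound 4 (0.27 log units; within the scatter) and a 1.1-fold higher number from compound 1 to compound 4 (0.04 log units; within the scatter) both stay within the scatter, as does the earlier step between those two compounds. At this position on the aromatic carbon, bromo, methoxycarbonyl and (methanesulfonamido)methyl therefore cannot be told apart in this test, even though they differ in make-up, and compound 3 is the only one of the four that separates from the rest, while nothing available here explains why its group stands apart.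

The compounds shown leave open whether a carboxylic acid, a primary amide or another five-membered aromatic ring with hetero atoms, placed on this same carbon, would fall with compound 3 or with the other three. For the compounds shown here, they also leave open whether 2H-tetrazol-5-yl would stand apart in the same way on a core changed elsewhere, for example with a shorter chain in place of the one all four compounds share.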